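Urea series on the shared core: step to compound 4

This account rests on a few compounds, and the source may have more. Where it says the series, first, only, none or still open, it means among the compounds named here.

Three compounds share the same core and differ only in the aryl group on the nitrogen on an aromatic ring. In a functional assay on HCC827 cells (Homo sapiens) for inhibition, read by MTT assay, with a stated time of 48 h, tested at 10 uM (a higher number here means more inhibition at the concentration tested (going by the name of the read-out), a lower number less inhibition), compound 1 `CCc1ccc(Nc2cc(NC(=O)Nc3cc(OC)cc(OC)c3)ncn2)cc1` gives 66.2%. Compound 2 `COc1cc(NC(=O)Nc2cc(Nc3ccc(C)c(C)c3)ncn2)cc(OC)c1` gives 45.7% in this assay, and compound 3 `COc1cc(NC(=O)Nc2cc(Nc3ccc(F)c(Cl)c3)ncn2)cc(OC)c1` gives 53.1%. Compound 3 thus stands second of the three: the step of a number 13.1 percentage points lower from compound 1 to compound 3 (beyond the scatter) lies beyond the scatter, whereas a number 7.4 percentage points higher from compound 2 to compound 3 (within the scatter) lies within it, so compound 2 and compound 3 cannot be ordered against each other. The step of a number 20.5 percentage points lower from compound 1 to compound 2 (beyond the scatter) is the larger of the two changes away from compound 1.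

Compound 4 `COc1cc(NC(=O)Nc2cc(Nc3ccc(C)c(F)c3)ncn2)cc(OC)c1` is not yet measured. It differs from compound 3 by 3-fluoro-4-methylphenyl in place of 3-chloro-4-fluorophenyl on a nitrogen on an aromatic ring. Both measured steps that bear on it, a number 20.5 percentage points lower from compound 1 to compound 2 (beyond the scatter) and a number 13.1 percentage points lower from compound 1 to compound 3 (beyond the scatter), concern exchanges among substituted aryl groups at this same position, and the two substituted-pair compounds sit within the scatter of each other. The incoming group shares one substituent with each of compound 2 and compound 3, so no step beyond the scatter is expected in this assay.

Compound 4 is therefore estimated at 50% in this assay, within 36% to 64%, an expected step of a number 3.1 percentage points lower from compound 3 to compound 4 (within the scatter).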

Compound 4, a percentage reported as inhibition, at one concentration (the size of the read-out at that concentration, not a potency): 72%
Compound 4: the middle estimate sits 22 percentage points below what was measured; measured number outside the range, above it.
By their numbers in this assay, from the lowest: compounds 2 and 3 (each within the scatter of the next); then compounds 1 and 4 (each within the scatter of the next).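

In this assay, this position responds strongly to a small exchange on the aryl group: a number 26.3 percentage points higher from compound 2 to compound 4 (beyond the scatter), with fluoro in place of methyl on an aromatic carbon, and a number 18.9 percentage points higher from compound 3 to compound 4 (beyond the scatter), with 3-fluoro-4-methylphenyl in place of 3-chloro-4-fluorophenyl, so sharing one substituent with each of compound 2 and compound 3 does not place compound 4 with them. With a number 5.8 percentage points higher from compound 1 to compound 4 (within the scatter), 3-fluoro-4-methylphenyl and 4-ethylphenyl cannot be ordered against each other, and the number of substituents on the aryl group does not track the reading, with compound 4 going against any such pattern when set beside compound 2 and compound 3. Nothing at hand gives a reason for these steps.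

The compounds shown leave open whether the reading at this position depends on the pairing of fluoro with methyl or on one of the two alone, which a plain 4-methylphenyl and a plain 3-fluorophenyl would help to separate. Also open, from the compounds shown here alone, is how this aryl group would read carrying an amine, a carboxylic acid or a longer chain such as propyl.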